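A few compounds are considered here, and "the series" means these few. Any claim that something is new, unique, unknown or untested is made for them only; others in the source may bear on it.

This account follows the step from compound 2 to compound 3. Compound 1 `C=CCONC(=O)CN1C(=O)S/C(=C\c2ccc(C(=O)N[C@@H](CC(C)C)C(=O)OC)cc2)C1=O` was tested in a functional assay on RAW264.7 cells (Mus musculus) for inhibition, read by microscopy and resazurin assay, with a stated time of 72 h (on this read-out higher numbers stand for weaker inhibition and lower numbers for stronger inhibition), and reaches only the limit of the assay at > 128000 nM rather than a number. Compound 2 `C=CCONC(=O)Cn1cc(C(=O)NCC(=O)N[C@@H](CC(C)C)C(=O)O)c2ccccc21` carries the same side arm on a different core. In this assay compound 2 likewise gives only a limit at > 128000 nM and no number. Compound 2 therefore stands at the limit of the assay, as does every value known here: the limit of > 128000 nM in this assay, at which 2 of the 2 values shown sit, summarises this. Compound 3 `C=CCONC(=O)Cn1cc(C(=O)N[C@@H](C)C(=O)N[C@@H](CC(C)C)C(=O)O)c2ccccc21` differs from compound 2 by methyl in place of hydrogen on a saturated chain carbon bound to an amide-type nitrogen and a carbonyl carbon. Within the data shown here, no measured step accompanies such a change, so no shift beyond the scatter is expected. The step expected here is a step that the limit leaves unreadable from compound 2 to compound 3 and stays within the scatter. Compound 3 is estimated at 150000 nM with 60000 nM as its lower end and 400000 nM as its upper end.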

Compound 3, half-maximal inhibitory concentration: > 128000 nM
Compound 3: no number, only a limit; the forecaster's own chance of this, stated with the estimate: 85%; the middle value lies beyond the limit too.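

Among these compounds, compound 2 and compound 3 both give only a limit and no number, so no step between them can be read. The compounds shown leave open whether methyl in place of hydrogen on this saturated chain carbon changes inhibition at all.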